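Methoxy for Bromo on an Anilinopyrimidine Series

This account rests on a few compounds, and the source may have more. Where it says the series, first, only, none or still open, it means among the compounds named here.

Measured compounds in an assay on isolated protein for inhibition of phosphatidylinositol 4,5-bisphosphate 3-kinase catalytic subunit beta isoform (Homo sapiens); a higher number here means a weaker inhibitor, a lower number a stronger inhibitor:
compound 1, `O=[N+]([O-])c1ccc(Nc2nccc(-c3ccc(F)cc3)n2)cc1`, 863 nM
compound 2, `COc1cccc(Nc2nccc(-c3ccc(Br)cc3)n2)c1`, 977 nM
compound 3, `Clc1ccc(Nc2nccc(-c3ccc(Br)cc3)n2)cc1`, 946 nM

The three measured compounds share a core and differ in the groups on their two outer rings. Among the compounds with values here, compound 2 gives 977 nM in this assay; compounds 1 and 3 give numbers that lie within the usual scatter of that of compound 2, so compound 2 is not set apart from either of them, and no step between any pair of the measured compounds is quantified here.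

Compound 4, `COc1ccc(-c2ccnc(Nc3cccc(OC)c3)n2)cc1`, is yet to be measured. Compared with compound 2 it carries methoxy in place of bromo on an aromatic carbon. Within the data shown here, nothing among the measured compounds shows what such an exchange does to the numbers in this assay, so the expected step is cautious: compound 4 is estimated to differ from compound 2 by a 1.2-fold higher number from compound 2 to compound 4 (0.09 log units; within the scatter), a step that may well not exceed the scatter. Compound 4 is therefore expected to give about 1200 nM in this assay, with a range from 400 nM to 3500 nM.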

Compound 4, half-maximal inhibitory concentration: 729 nM
Compound 4: middle estimate off by 1.6-fold (0.22 log units), on the high side; low and high end bracket the measured number.
By their numbers in this assay, from the lowest: compounds 4, 1, 3 and 2 (each within the scatter of the next).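

In this assay, within the data shown here, the exchange of bromo for methoxy on an aromatic carbon, para to a large group, gives the first step in this set that can be read for one change in one place: a 1.3-fold lower number from compound 2 to compound 4 (0.13 log units; within the scatter). At this position the pair does not separate the two groups, although methoxy brings a hydrogen-bond acceptor that bromo does not have. Nothing at hand accounts for how close the two numbers lie.

The compounds shown leave open whether a group of another kind at this position, such as an amine or a carboxylic acid, would move the number beyond the scatter. They also leave open whether bromo and methoxy would stay this close if the other outer ring carried something other than the methoxy shared by compound 2 and compound 4.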